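A few compounds are considered here, and "the series" means these few. Any claim that something is new, unique, unknown or untested is made for them only; others in the source may bear on it.

Measured so far in a functional assay on HeLa cells (Homo sapiens) for antiproliferative activity, read by MTT assay, with a stated time of 72 h; on this read-out lower numbers stand for stronger inhibition and higher numbers for weaker inhibition:
compound 1 `COc1ccc(N2C(=O)COc3ccc(-c4cnc(Cl)c(NS(=O)(=O)c5ccc(F)cc5)c4)cc32)cc1` gives 8320 nM.
compound 3 `Cc1ccc(N2C(=O)COc3ccc(-c4cnc(Cl)c(NS(=O)(=O)c5ccc(F)cc5)c4)cc32)cc1` gives 32300 nM.
compound 2 `Cc1ccc(N2C(=O)COc3ccc(-c4cnc5ccccc5c4)cc32)cc1` gives only a limit of the assay, > 40000 nM.

Compounds 1 and 3 share one core; compound 2 carries another, and the difference between the two cores is not broken down here. Between compound 3 and compound 1 the change is methoxy in place of methyl on an aromatic carbon, and in this assay it gives a 3.9-fold lower number from compound 3 to compound 1 (0.59 log units; beyond the scatter).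

Compound 4 `COc1ccc(N2C(=O)COc3ccc(-c4cnc5ccccc5c4)cc32)cc1` is not yet measured. It differs from compound 2 by methoxy in place of methyl on an aromatic carbon, the same change as from compound 3 to compound 1, at the same place on the ring. Compound 2 stands at the limit of > 40000 nM in this assay, at which 1 of the 3 values shown sits, which is a limit and not a number, and the same holds for the starting point of the new pair. Among the measured compounds shown here, the only measured instance of this change is the step from compound 3 to compound 1, and on that alone rests the expectation for compound 4. The step from compound 2 to compound 4 is expected to be about an at least 1.3-fold lower number from compound 2 to compound 4 (0.12 log units; that floor lies within the scatter). Compound 4 is therefore estimated at 30000 nM in this assay, with a range from 10000 nM to 80000 nM, and a fair chance that the assay again reports only a limit.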

Compound 4, half-maximal inhibitory concentration: > 40000 nM
Compound 4 was reported as a limit; the forecaster's own chance of this, stated with the estimate: 45%; at least 1.3-fold (0.12 log units) between middle value and limit.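

Compound 2 and compound 4 both sit at the limit in this assay, so no step between them can be read: the limit of > 40000 nM in this assay, at which 2 of the 4 values shown sit.

The compounds shown leave open whether the change from 4-methylphenyl to 4-methoxyphenyl shifts the number at all on the core shared by compound 2 and compound 4, as it does on the core of compound 1.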